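Ring size and bromine position in the shared core

A few compounds are considered here, and "the series" means these few. Any claim that something is new, unique, unknown or untested is made for them only; others in the source may bear on it.

Compound 1 `O=C(CN1CCCC1)Nc1ccc2ncnc(Nc3cccc(Br)c3)c2c1` is tested in a functional assay on MCF7 cells (Homo sapiens) for antiproliferative activity, read by MTT assay, with a stated time of 48 h (a higher number here means a weaker inhibitor, a lower number a stronger inhibitor), where compound 1 gives 12000 nM. Compound 2 `O=C(CN1CCCCC1)Nc1ccc2ncnc(Nc3cccc(Br)c3)c2c1` differs by piperidin-1-yl in place of pyrrolidin-1-yl on a saturated chain carbon bound to a carbonyl carbon; in this assay compound 2 gives 3000 nM, a step of a 4.0-fold lower number from compound 1 to compound 2 (0.60 log units; beyond the scatter). Compound 3 `O=C(CN1CCCC1)Nc1ccc2ncnc(Nc3ccc(Br)cc3)c2c1` carries 4-bromophenyl in place of 3-bromophenyl on a nitrogen on an aromatic ring. In this assay compound 3 reaches only a limit, > 100000 nM. The step of an at least 8.3-fold higher number from compound 1 to compound 3 (0.92 log units; beyond the scatter) is therefore bounded from one side only (the limit of > 100000 nM in this assay, at which 1 of the 3 values shown sits). Compound 4 `O=C(CN1CCCCC1)Nc1ccc2ncnc(Nc3ccc(Br)cc3)c2c1` is not yet measured; it differs from compound 3 by piperidin-1-yl in place of pyrrolidin-1-yl on a saturated chain carbon bound to a carbonyl carbon, the same change as from compound 1 to compound 2, at the same place. Because the earlier step was a 4.0-fold lower number from compound 1 to compound 2 (0.60 log units; beyond the scatter), a gain of similar size is expected for compound 4, read as an at least 1.6-fold lower number from compound 3 to compound 4 (0.22 log units; that floor lies within the scatter), though the limit for compound 3 leaves the starting point open. Compound 4 is estimated at 60000 nM, between 15000 nM and 300000 nM.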

Compound 4, half-maximal inhibitory concentration: > 100000 nM
Compound 4: a limit, no number (the forecaster's own chance of this, stated with the estimate: 45%); at least 1.6-fold (0.22 log units) between middle value and limit.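

With the limits on both compound 3 and compound 4, the step from pyrrolidin-1-yl to piperidin-1-yl cannot be read with 4-bromophenyl in place, so the gain seen with 3-bromophenyl is neither confirmed nor refuted there. The change from 3-bromophenyl to 4-bromophenyl carries over in direction, with an at least 33-fold higher number from compound 2 to compound 4 (1.52 log units; beyond the scatter), but its size on the two cores cannot be compared: the same change on two cores in this assay, an at least 8.3-fold higher number (0.92 log units; beyond the scatter) from compound 1 to compound 3 and an at least 33-fold higher number (1.52 log units; beyond the scatter) from compound 2 to compound 4; the limit leaves it open whether they differ. In this assay the two 4-bromophenyl compounds give no numbers, only a limit: the limit of > 100000 nM in this assay, at which 2 of the 4 values shown sit.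

On these data alone, it remains open whether any saturated ring on this chain gives a measurable number with 4-bromophenyl in place. Morpholin-4-yl in place of piperidin-1-yl, or a longer chain, also remains open with 3-bromophenyl.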